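This account rests on a few compounds, and the source may have more. Where it says the series, first, only, none or still open, it means among the compounds named here.

Measured compounds:
compound 1, `COc1ccccc1/C=c1/[nH]c(=O)/c(=C\c2ccccc2OC)n(C)c1=O` — 7000 nM in a functional assay on A549 cells (Homo sapiens) for cytotoxicity, read by CCK-8 assay, with a stated time of 72 h; on this read-out higher numbers stand for weaker inhibition and lower numbers for stronger inhibition
compound 2, `C=CCn1c(=O)/c(=C\c2ccc(Cl)c(Cl)c2)[nH]c(=O)/c1=C\c1ccccc1OC` — "not active" (no number reported) in this assay, with no number given
compound 3, `C=CCn1c(=O)/c(=C\c2cccc(Br)c2)[nH]c(=O)/c1=C\c1ccccc1OC` — 5400 nM in this assay

Of the three measured compounds, only compound 1 and compound 3 carry a numerical value in this assay, and those two values lie within the usual scatter of each other. Compound 2 stands apart: in this assay it was reported as not active, and no value was given for it, so its distance from the other two cannot be put into numbers.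

Compound 4, `C=CCn1c(=O)/c(=C\c2ccc(C)cc2)[nH]c(=O)/c1=C\c1ccccc1OC`, differs from compound 2 in one place: 4-methylphenyl in place of 3,4-dichlorophenyl on a double-bonded chain carbon bound to an aromatic carbon. Among the compounds with values here, no measured pair shows what this change does in this assay. With compound 2 giving no number, the direction and size of the step from compound 2 to compound 4 cannot be anchored on a measured value; what can be said is that the two compounds with numbers, compound 1 and compound 3, both sit in the same weak range, and compound 4 shares the rest of the core with them.

On that basis compound 4 is expected to fall near that range, with an estimate of 8000 nM and a likely span from 2500 nM to 30000 nM, allowing for the chance that it too is reported only as not active.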

Compound 4, half-maximal inhibitory concentration: "not active" (no number reported)
Nothing numeric was reported for compound 4; no gap can be computed for the estimate.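

Compound 4, like compound 2, was reported as not active in this assay with no number given, so no step can be read from the change from 3,4-dichlorophenyl to 4-methylphenyl. The compounds shown leave open whether this change alters the activity at all. No measured evidence shown here bears on this result.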